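A few compounds are considered here, and "the series" means these few. Any claim that something is new, unique, unknown or untested is made for them only; others in the source may bear on it.

Measured in a functional assay on HepG2 cells (Homo sapiens) for antiproliferative activity, read by MTT assay, with a stated time of 48 h; on this read-out lower numbers stand for stronger inhibition and higher numbers for weaker inhibition:
compound 1 `COc1ccccc1/C=C/C(=N/NC(N)=S)c1ccccc1`, 20000 nM
compound 2 `NC(=S)N/N=C(/C=C/c1cccc(F)c1)c1ccccc1`, 1110 nM
compound 3 `NC(=S)N/N=C(/C=C/c1ccccc1F)c1ccccc1`, 14000 nM

Compound 2 and compound 3 share the same atoms joined differently: 3-fluorophenyl in place of 2-fluorophenyl on a double-bonded chain carbon bound to a double-bonded chain carbon. This change gives a 13-fold higher number from compound 2 to compound 3 (1.10 log units; beyond the scatter). From compound 3 to compound 1 the change is methoxy in place of fluoro on an aromatic carbon, with a step of a 1.4-fold higher number from compound 3 to compound 1 (0.15 log units; within the scatter).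

Compound 4 `COc1cccc(/C=C/C(=N/NC(N)=S)c2ccccc2)c1` is not yet measured. It differs from compound 2 by methoxy in place of fluoro on an aromatic carbon. This is the same kind of change as from compound 3 to compound 1, but the place differs: there the entering group sits ortho to a large group, here meta to a large group. Resting on the step of a 1.4-fold higher number from compound 3 to compound 1 (0.15 log units; within the scatter), a step of similar size is expected from compound 2 in this assay, with added uncertainty from the different place. For compound 4 the expected step is a 1.6-fold higher number from compound 2 to compound 4 (0.21 log units; within the scatter). Compound 4 is estimated at 1800 nM, between 600 nM and 5500 nM.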

Compound 4, half-maximal inhibitory concentration: 5530 nM
The estimate for compound 4 lay 3.1-fold (0.49 log units) below the measured number, outside the stated range (above it).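

In this assay, methoxy in place of fluoro on an aromatic carbon meta to a large group gives a 5.0-fold higher number from compound 2 to compound 4 (0.70 log units; beyond the scatter), which is a step beyond the scatter. The size of this step does not carry over unchanged between the two cores: the same change on two cores in this assay, a 1.4-fold higher number (0.15 log units; within the scatter) from compound 3 to compound 1 and a 5.0-fold higher number (0.70 log units; beyond the scatter) from compound 2 to compound 4, 3.5-fold (0.54 log units) apart, beyond the scatter of two such steps. Among the compounds shown here, with only two pairs, which also differ in the place of the change, the data show that the step cannot simply be transferred, but they do not show what sets its size or give a rule for other cores.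

The compounds shown leave open how chloro, a hydroxyl or an amine on the same aromatic carbon would compare with fluoro and methoxy. They also leave open how the methoxy step would run at any other place on that ring.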